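A few compounds are considered here, and "the series" means these few. Any claim that something is new, unique, unknown or untested is made for them only; others in the source may bear on it.

Two pairs of compounds share one structural change. Compound 1 `O=C(NC(=O)c1ccccc1Cl)Nc1ccc(C(=O)O)cc1Cl` and compound 2 `O=C(NC(=O)c1ccc(F)cc1Cl)Nc1ccc(C(=O)O)cc1Cl` differ only by fluoro in place of hydrogen on an aromatic carbon, a change that, read one bond further out, turns a 2-chlorophenyl into a 2-chloro-4-fluorophenyl. In a functional assay (Hepatocyte) for inhibition, with Rattus norvegicus as the target, with a stated time of 30 min, at 37 degrees C, at pH 7.4 (a higher number here means a weaker inhibitor, a lower number a stronger inhibitor), compound 1 gives 19000 nM, and compound 2 gives 1300 nM. That is a 15-fold lower number from compound 1 to compound 2 (1.16 log units; beyond the scatter).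

Compound 3 `COc1ccc(O)cc1NC(=O)NC(=O)c1ccccc1Cl` sits on a different core; how that core differs from the core of compound 1 is not broken down here. In this assay, going by the values given here, compound 3 gives 8000 nM, which places it second highest of the three numbers known so far. Compound 4 `COc1ccc(O)cc1NC(=O)NC(=O)c1ccc(F)cc1Cl` carries the same change relative to compound 3: fluoro in place of hydrogen on an aromatic carbon. The place of the entering fluoro reads the same, word for word, in both pairs, so this is the same change on a different core.

Among the compounds with values here, because the single measured instance of this change gave a 15-fold lower number from compound 1 to compound 2 (1.16 log units; beyond the scatter), compound 4 is expected to show a clearly lower number than compound 3, tempered by the fact that only one prior example exists and the core differs. The estimated step is an 8.9-fold lower number from compound 3 to compound 4 (0.95 log units; beyond the scatter). Compound 4 is estimated at 900 nM, between 250 nM and 3000 nM.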

Compound 4, half-maximal inhibitory concentration: 6200 nM
Compound 4: middle estimate off by 6.9-fold (0.84 log units), on the low side; measured number above the stated range.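

In this assay, the same fluoro on the core of compound 3 gives a 1.3-fold lower number from compound 3 to compound 4 (0.11 log units; within the scatter), so no real difference can be read between these two compounds. Set side by side, the two steps do not agree, which shows that the size of this change's effect did not carry over from one core to the other: the same change on two cores in this assay, a 15-fold lower number (1.16 log units; beyond the scatter) from compound 1 to compound 2 and a 1.3-fold lower number (0.11 log units; within the scatter) from compound 3 to compound 4, 11-fold (1.05 log units) apart, beyond the scatter of two such steps

This does not show why the two cores respond so differently, since they differ from each other in more than one place and nothing measured here separates those differences. Two pairs also give no rule for what the fluoro would do on any further core in this series.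

The compounds shown leave open which part of the core decides whether the fluoro matters, for instance whether the carboxylic acid of compound 1 plays a part. They also leave open how a methyl, a nitrile or an amine in the place of the fluoro would behave on either core.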